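Bromo in Place of Hydrogen on the Anilide Ring

This account rests on a few compounds, and the source may have more. Where it says the series, first, only, none or still open, it means among the compounds named here.

Measured so far:
compound 1, `O=C(Nc1ccccc1)c1csc(Cc2c(Cl)cccc2Cl)n1`: > 4000 nM
compound 2, `CN(C)c1ccc(NC(=O)c2csc(Cc3c(Cl)cccc3Cl)n2)cc1`: 1270 nM

In an assay on CHO cells, read by calcium flux (a higher number here means a weaker inhibitor, a lower number a stronger inhibitor), compound 1 gives only a limit, not a number. As far as these compounds go, it therefore stands at the limit of > 4000 nM in this assay, at which 1 of the 2 values shown sits, and its true value is unknown. Compound 3, `O=C(Nc1ccc(Br)cc1)c1csc(Cc2c(Cl)cccc2Cl)n1`, differs from compound 1 by bromo in place of hydrogen on an aromatic carbon. Among the measured compounds shown here, the one measured step, an at least 3.1-fold lower number from compound 1 to compound 2 (0.49 log units; beyond the scatter), concerns dimethylamino, a different group; no step with bromo exists. Bromo at the same place is expected to give, at most, a smaller gain, an at least 1.6-fold lower number from compound 1 to compound 3 (0.20 log units; that floor lies within the scatter). Compound 3 is expected to reach 2500 nM, between 800 nM and 8000 nM.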

Compound 3, half-maximal inhibitory concentration: 460 nM
The estimate for compound 3 lay 5.4-fold (0.74 log units) above the measured number; measured number below the stated range.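

In this assay, among the compounds shown here, bromo in place of hydrogen gives an at least 8.6-fold lower number from compound 1 to compound 3 (0.93 log units; beyond the scatter) and so shows that dimethylamino is not the only group on this aromatic carbon that goes with a lower number. Bromo in place of dimethylamino gives a 2.8-fold lower number from compound 2 to compound 3 (0.44 log units; beyond the scatter) and so shows that the choice of group here still counts, with a single bromine atom ahead of dimethylamino. The first of these steps has no upper end, since compound 1 gives only a limit: the limit of > 4000 nM in this assay, at which 1 of the 3 values shown sits.

Still open, as far as these compounds go, is whether chloro, methoxy or a carboxylic acid on the same carbon would give a lower number still, and whether bromo would do as well on another carbon of this ring.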